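A Methoxy Shift and Its Effect on Cell Growth Inhibition

The source may hold more compounds than are shown below. What is called first, only, known or untested is meant among the compounds shown, and "the series" means these compounds.

compound 1 `COc1ccc(C(=O)c2sc(Nc3ccccc3)nc2N)cc1OC`: > 10000 nM
compound 2 `COc1cccc(C(=O)c2sc(Nc3ccccc3)nc2N)c1`: 6200 nM
compound 3 `COc1ccccc1C(=O)c1sc(Nc2ccccc2)nc1N`: 1100 nM

Of the compounds shown here, three have been measured in a functional assay on FM3A cells (Mus musculus) for antiproliferative activity, read by cell counting, with a stated time of 2 days; on this read-out higher numbers stand for weaker inhibition and lower numbers for stronger inhibition. Compound 1 reaches only a limit of the assay, > 10000 nM, which is the limit of > 10000 nM in this assay, at which 1 of the 3 values shown sits. Compound 2 gives 6200 nM, and compound 3 gives 1100 nM, the lowest of the two numbers. Compounds 2 and 3 hold the same atoms joined differently; the difference between the two cores is not broken down here. From compound 2 to compound 1 the change is methoxy in place of hydrogen on an aromatic carbon, and the step it made is an at least 1.6-fold higher number from compound 2 to compound 1 (0.20 log units; that floor lies within the scatter).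

Compound 4 `COc1ccc(Nc2nc(N)c(C(=O)c3ccccc3OC)s2)cc1` has not yet been measured. From compound 3 it differs by methoxy in place of hydrogen on an aromatic carbon. Within the data shown here, this is the same kind of change as the one from compound 2 to compound 1, but not the same: there the entering group sat ortho to a methoxy group, here it does not. Resting on an at least 1.6-fold higher number from compound 2 to compound 1 (0.20 log units; that floor lies within the scatter), compound 4 is expected to show a step of similar size, a 1.8-fold higher number from compound 3 to compound 4 (0.26 log units; within the scatter). Compound 4 is therefore estimated at 2000 nM, between 600 nM and 7000 nM.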

Compound 4, half-maximal inhibitory concentration: 52 nM
Beside the measured number, compound 4's estimate is 38-fold (1.59 log units) above it; measured number below the stated range.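

In this assay, methoxy in place of hydrogen, here phenyl to 4-methoxyphenyl, gives a 21-fold lower number from compound 3 to compound 4 (1.33 log units; beyond the scatter). Set beside the earlier step, the same kind of change does not carry its size from one core to the other: the same change on two cores in this assay, an at least 1.6-fold higher number (0.20 log units; that floor lies within the scatter) from compound 2 to compound 1 and a 21-fold lower number (1.33 log units; beyond the scatter) from compound 3 to compound 4, at least 34-fold (1.53 log units) apart, beyond the scatter of two such steps This shows that, among these compounds, a step measured on one core was no guide to the step on another, but it does not show which difference accounts for the gap, the core or the place where the methoxy enters, and the earlier step is only a floor, as the number for compound 1 is a limit of the assay.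

The compounds shown leave open whether the large step belongs to methoxy itself or would also appear with another group in the same place, such as an amine, a carboxylic acid or the longer ethoxy. They also leave open whether 4-methoxyphenyl would bring a similar step on the core of compound 2.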